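Mirror image of compound 1: notes on compound 4

The source may report more compounds than this note shows. Statements on the series, on what has been measured and on what is new or still open speak of the compounds shown alone.

Compound 1 `O=C1c2c(O)cccc2O[C@H](c2cccc(O)c2O)[C@H]1O` gives 77700 nM in a functional assay on RAW264.7 cells (Rattus norvegicus) for inhibition, with RAW264.7 (Mus musculus) as the target, read by Griess assay, with stated times of 2 h and 16 h; a higher number here means a weaker inhibitor, a lower number a stronger inhibitor.
Compound 2 `COc1ccc2c(c1)O[C@@H](c1cccc(O)c1O)[C@H](O)C2=O` gives 30300 nM in this assay.
Compound 3 `O=C1c2ccccc2O[C@H](c2cccc(O)c2O)[C@H]1O` reaches only the limit > 100000 nM in this assay; a limit, not a number.

Among the two numbers, compound 1 stands highest; compound 2 sits lower by a gap beyond the scatter. Going by the values given here, the single measured step, an at least 1.2-fold higher number from compound 1 to compound 3 (0.10 log units; that floor lies within the scatter), concerns a substituent, not configuration, and runs into the limit (the limit of > 100000 nM in this assay, at which 1 of the 3 values shown sits). Compound 4 `O=C1c2c(O)cccc2O[C@@H](c2cccc(O)c2O)[C@@H]1O` differs from compound 1 in this: the two compounds have the same atoms and bonds and differ only in configuration as drawn: 2 of 2 stereo elements differ (all stereocentres are inverted: mirror images); a stereocentre at a saturated ring carbon is drawn R in compound 1 and S in compound 4; a stereocentre at a saturated ring carbon is drawn R in compound 1 and S in compound 4. Among the compounds with values here, no measured step bears on inverting both stereocentres, so no direction of change can be grounded; compound 4 is expected near compound 1, with a wide range, a 1.0-fold higher number from compound 1 to compound 4 (0.01 log units; within the scatter). Compound 4 is estimated at 80000 nM, between 25000 nM and 250000 nM.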

Compound 4, half-maximal inhibitory concentration: > 100000 nM
Compound 4 ended at the assay's limit; the forecaster's own chance of this, stated with the estimate: 35%; at least 1.2-fold (0.09 log units) between middle value and limit.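

Compound 4 gives > 100000 nM in this assay as a limit, not a number. Inverting both stereocentres, the first change of configuration measured in this series, gives an at least 1.2-fold higher number from compound 1 to compound 4 (0.10 log units; that floor lies within the scatter) and so brings no fall in the number, though the rise is not established beyond the scatter. The mirror image therefore offers no gain over compound 1, while any real loss cannot be sized.

Going by these compounds, how far compound 4 lies past the limit stays open, as does the effect of inverting only one stereocentre. Also open, on these data alone, is how an amine or a carboxylic acid in place of a hydroxy on the core of compound 1 would read.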